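The compounds below may be only part of what the source reports. "The series", "measured", "known", "first", "only" and "open" are said of these compounds alone.

Compound 2 `COc1ccccc1C1C(C#N)=C(N)N(c2ccc(S(N)(=O)=O)cc2)C2=C1CCCC2` and compound 1 `Cc1ccc(C2C(C#N)=C(N)N(c3ccc(S(N)(=O)=O)cc3)C3=C2CCCC3)cc1` share one core. In a functional assay on Ehrlich cells (Mus musculus) for cytotoxicity, read by trypan blue exclusion, with a stated time of 2 h, tested at 25 ug/mL (on this read-out lower numbers stand for a weaker effect and higher numbers for a stronger effect at the one concentration tested), compound 2 gives 40%, and compound 1 gives 30%. These two numbers lie within the scatter of each other, so neither compound can be called the more active. Within the data shown here, the single measured step, a number 10 percentage points higher from compound 1 to compound 2 (within the scatter), is likewise within the scatter. Compound 3 `COc1ccc(C2C(C#N)=C(N)N(c3ccc(S(N)(=O)=O)cc3)C3=C2CCCC3)cc1` differs from compound 2 by 4-methoxyphenyl in place of 2-methoxyphenyl on a saturated ring carbon. Among the measured compounds shown here, no measured step exchanges one methoxyphenyl for another, so nothing points beyond the scatter in either direction. The expected step is a number 5 percentage points lower from compound 2 to compound 3 (within the scatter). Compound 3 is therefore estimated to give 35%, with a range from 15% to 55%.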

Compound 3, a percentage reported as activity, at one concentration (the size of the read-out at that concentration, not a potency): 90%
Estimate against measurement, compound 3: 55 percentage points below; measured number above the stated range.
By their numbers in this assay, from the lowest: compounds 1 and 2 (each within the scatter of the next); then compound 3.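

Swapping 2-methoxyphenyl for 4-methoxyphenyl on this saturated ring carbon gives a number 50 percentage points higher from compound 2 to compound 3 (beyond the scatter) in this assay, so with the same atoms, where the methoxy sits on the phenyl ring matters here. Methoxy in place of methyl on the aromatic carbon, with the substituent placement of 4-methylphenyl kept, gives a number 60 percentage points higher from compound 1 to compound 3 (beyond the scatter) in the same read-out, so the identity of the group matters too. Nothing at hand explains either step. The compounds shown leave open whether 4-ethoxyphenyl or 4-hydroxyphenyl would keep this level of effect, and how a 4-aminophenyl group would compare.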